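Aryl ether series: methyl, methoxy, chloro compared

The compounds below may be only part of what the source reports. "The series", "measured", "known", "first", "only" and "open" are said of these compounds alone.

Measured so far:
compound 1 `Cc1ccccc1Oc1ccc2nncn2n1`: 54.8 mg/kg
compound 2 `COc1ccccc1Oc1ccc2nncn2n1`: > 100 mg/kg

In a functional assay on the whole organism with Mus musculus as the target (on this read-out lower numbers stand for an effect already at smaller amounts and higher numbers for an effect only at larger amounts of compound), compound 1 gives 54.8 mg/kg. For compound 2 the assay reports only a limit, > 100 mg/kg, and not a number. That limit is the limit of > 100 mg/kg in this assay, at which 1 of the 2 values shown sits. Compound 2 therefore stands at the edge of the measured range: the step of an at least 1.8-fold higher number from compound 1 to compound 2 (0.26 log units; that floor lies within the scatter) has a floor that lies within the scatter, and how far beyond that floor compound 2 really lies is not known.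

Compound 3 `Clc1ccccc1Oc1ccc2nncn2n1` is not yet measured. It differs from compound 2 by chloro in place of methoxy on an aromatic carbon. The leaving methoxy carries one hydrogen-bond acceptor, the entering chloro none. Among the measured compounds shown here, the only measured step that bears on this position is an at least 1.8-fold higher number from compound 1 to compound 2 (0.26 log units; that floor lies within the scatter), which moved toward higher numbers but only to a floor within the scatter, so no direction beyond the scatter can be read from it. For compound 3 a value near the two measured compounds is expected, estimated at 70 mg/kg with a range from 30 mg/kg to 160 mg/kg. The expected step is an at least 1.4-fold lower number from compound 2 to compound 3 (0.15 log units; that floor lies within the scatter), with a fair chance that the assay again reports only a limit.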

Compound 3, dose for half-maximal effect: 47.3 mg/kg
Beside the measured number, compound 3's estimate is 1.5-fold (0.17 log units) above it, and the stated range covers the measured number.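

At this position, ortho to a large group, chloro in place of methoxy gives a step that is read as beyond the scatter in this assay: an at least 2.1-fold lower number from compound 2 to compound 3 (0.32 log units; beyond the scatter). The value of compound 2 is a limit and not a number, and the step built on it is therefore only a floor: the limit of > 100 mg/kg in this assay, at which 1 of the 3 values shown sits. Chloro and methyl on the same aromatic carbon cannot be told apart in this series, with a 1.2-fold lower number from compound 1 to compound 3 (0.06 log units; within the scatter), and methoxy is separated from chloro by a step beyond the scatter but from methyl only by a floor within it.

On these data alone, three compounds cannot show whether the separation of compound 2 follows the hydrogen-bond acceptor that leaves with methoxy or the larger heavy-atom count of that group, and how far compound 2 really lies past its limit remains unknown. As far as these compounds go, it also remains open whether an amine, a carboxylic acid or a longer chain such as ethoxy at this position would stay level with compound 1 and compound 3 or would part from them.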